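Sulfonate Esters on a Shared Core

The compounds below may be only part of what the source reports. "The series", "measured", "known", "first", "only" and "open" are said of these compounds alone.

Measured so far:
- Compound 1, `CCC(CC)(c1ccc(OCCCCO)c(C)c1)c1ccc(OCC(O)C(C)(C)C)c(OCC(O)C(C)(C)C)c1`: 71%
- Compound 2, `CCC(CC)(c1ccc(OS(C)(=O)=O)c(C)c1)c1ccc(OCC(O)C(C)(C)C)c(OCC(O)C(C)(C)C)c1`: "not active" (no number reported)

Both compounds were tested in an assay on cells for binding affinity to vitamin D3 receptor (Homo sapiens), read by fluorescence, tested at 1 uM; on this read-out lower numbers stand for less inhibition and higher numbers for more inhibition at the one concentration tested (going by the name of the read-out). Compound 1 gives 71% there. Compound 2 is reported only as "not active" (no number reported), so no number stands for it, and there is nothing to place it against compound 1 on a common scale other than that it was recorded without activity while compound 1 was recorded with a value.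

Compound 3, `CCC(CC)(c1ccc(OS(=O)(=O)c2ccc([N+](=O)[O-])cc2)c(C)c1)c1ccc(OCC(O)C(C)(C)C)c(OCC(O)C(C)(C)C)c1`, has not been measured. It differs from compound 2 in one place: 4-nitrophenyl in place of methyl on a sulfonyl sulfur. Going by the values given here, no step between two measured compounds matches this change, so there is no measured pattern to lean on. Because compound 2 gives "not active" (no number reported), the starting point is low, and the expectation is for compound 3 to remain near it, with any shift in this assay likely no larger than the usual scatter, in either direction.

Compound 3 is estimated to give 12%, within a range of 0% to 40%.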

Compound 3, a percentage reported as inhibition, at one concentration (the size of the read-out at that concentration, not a potency): 29%
Estimate against measurement, compound 3: 17 percentage points below; the measured number falls inside the stated range.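

In this assay compound 3 gives 29% as a number, whereas compound 2 is recorded only as "not active" (no number reported) and so cannot be placed on the same scale; this shows that a sulfonyl group on this oxygen can still come with a measurable reading. Putting (4-nitrophenyl)sulfonyl in place of 4-hydroxybutyl on that oxygen gives a number 42 percentage points lower from compound 1 to compound 3 (beyond the scatter) and puts a first size on how much the group at this position can matter. No measurement here explains either reading.

The compounds shown leave open whether a plain phenyl on the sulfonyl sulfur, or an amine in place of the nitro group, would read like compound 3. They also leave open whether a carboxylic acid at the end of the chain on this oxygen would keep the reading of compound 1.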